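From acetyl to 1-(ethoxycarbonyl)ethyl on the shared core

The source may report more compounds than this note shows. Statements on the series, on what has been measured and on what is new or still open speak of the compounds shown alone.

Compound 1 `OCCCOc1c(Br)cc(Br)cc1Oc1ccc(Br)cc1Br` gives 32.3 ug/mL
Compound 2 `CC(=O)Oc1c(Br)cc(Br)cc1Oc1ccc(Br)cc1Br` gives 32.3 ug/mL

In a functional assay on U-937 cells (Homo sapiens) for cytotoxicity, read by MTT assay, with a stated time of 24 h (a lower number here means a stronger inhibitor, a higher number a weaker inhibitor), compound 2 gives 32.3 ug/mL and stands level with compound 1 at the digits reported. Compound 3 `CCOC(=O)C(C)Oc1c(Br)cc(Br)cc1Oc1ccc(Br)cc1Br` keeps the shared core and changes only the group on the oxygen: 1-(ethoxycarbonyl)ethyl in place of acetyl on an oxygen on an aromatic ring. In words, 1-(ethoxycarbonyl)ethyl stands in place of acetyl on an oxygen on an aromatic ring.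

Within the data shown here, only one measured step bears on this change. Acetyl replaces 3-hydroxypropyl on that same oxygen, and the result is no change at the digits printed from compound 1 to compound 2 (within the scatter). Among the measured compounds shown here, that is thin evidence, since it is a single pair and no measured compound carries the entering group. Even so, nothing in the data points to a direction, so no step beyond the scatter is expected in this assay. The estimated step is a 1.1-fold lower number from compound 2 to compound 3 (0.03 log units; within the scatter). For compound 3 the expected value is 30 ug/mL, with an estimated range from 14 ug/mL to 60 ug/mL.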

Compound 3, half-maximal inhibitory concentration: 39.5 ug/mL
Compound 3: the middle estimate sits 1.3-fold (0.12 log units) below what was measured, within the range that was stated.
By their numbers in this assay, from the lowest: compounds 1, 2 and 3 (each within the scatter of the next).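

In this assay, 1-(ethoxycarbonyl)ethyl in place of acetyl on an oxygen on an aromatic ring gives (a 1.2-fold higher number from compound 2 to compound 3 (0.09 log units; within the scatter)), and the same group in place of 3-hydroxypropyl gives (a 1.2-fold higher number from compound 1 to compound 3 (0.09 log units; within the scatter)). Compounds 1 and 2 alone offered a single swap on this oxygen, whereas three differently named groups now sit there, and the entering group is the largest of the two compared under this change without any step leaving the scatter, so no order among the three can be drawn. Nothing measured here explains why these groups read alike.

The compounds shown leave open whether a group of another kind on this oxygen, such as an amine or a carboxylic acid, or a longer chain than 3-hydroxypropyl, would give a step beyond the scatter. They also leave open how a free hydroxyl on that oxygen would read, and so whether the group there matters at all to the number in this cell assay or whether the shared core alone sets its level.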